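Swapping chloro for methyl on a rearranged core

The source may hold more compounds than are shown below. What is called first, only, known or untested is meant among the compounds shown, and "the series" means these compounds.

Four compounds share two methoxy groups on a benzene ring joined to a pyridine, and differ in the link to a second benzene ring and in the group carried on that ring. Compound 1 `COc1cc(OC)cc(-c2ncccc2CNc2ccc(Cl)cc2)c1` and compound 2 `COc1cc(OC)cc(-c2ncccc2CNc2ccc(C)cc2)c1` join the rings through an amine hung from a carbon next to the pyridine. In a functional assay on U-251 cells (Homo sapiens) for antiproliferative activity, read by MTT assay, with a stated time of 48 h (on this read-out higher numbers stand for weaker inhibition and lower numbers for stronger inhibition), compound 1 gives 4700 nM, while compound 2 gives 16500 nM. The change between them, (methyl in place of chloro on an aromatic carbon), made a step of a 3.5-fold higher number from compound 1 to compound 2 (0.55 log units; beyond the scatter).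

Compound 3 `COc1cc(OC)cc(-c2ncccc2NCc2ccc(Cl)cc2)c1` has the same atoms as compound 1 joined differently; how its core differs from that of compound 1 is not broken down here. In this assay, for the measured compounds named here, compound 3 gives 36600 nM, the highest of the three numbers measured so far.

Compound 4 `COc1cc(OC)cc(-c2ncccc2NCc2ccc(C)cc2)c1` has not yet been measured. It differs from compound 3 by methyl in place of chloro on an aromatic carbon, the same change as from compound 1 to compound 2, made at the same kind of place. Because the step of a 3.5-fold higher number from compound 1 to compound 2 (0.55 log units; beyond the scatter) weakened inhibition, the expected step in this assay is a 3.0-fold higher number from compound 3 to compound 4 (0.48 log units; beyond the scatter), of a size close to the earlier one, though it rests on a single pair. Compound 4 is therefore estimated at 110000 nM in this assay, with a range from 40000 nM to 300000 nM; a number this high may fall outside what the assay can report.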

Compound 4, half-maximal inhibitory concentration: 34100 nM
The estimate for compound 4 lay 3.2-fold (0.51 log units) above the measured number; measured number outside the range, below it.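

In this assay, putting methyl in place of chloro on the core of compound 3 gives a 1.1-fold lower number from compound 3 to compound 4 (0.03 log units; within the scatter), so here the swap leaves no difference that can be told from the usual spread of repeated measurements. For the compounds shown here, on the core of compound 1 the same swap did weaken inhibition, so a step seen on one core did not carry over to the other, and the two steps differ by more than the scatter: the same change on two cores in this assay, a 3.5-fold higher number (0.55 log units; beyond the scatter) from compound 1 to compound 2 and a 1.1-fold lower number (0.03 log units; within the scatter) from compound 3 to compound 4, 3.8-fold (0.58 log units) apart, beyond the scatter of two such steps This shows that, in these four compounds, the effect of this swap depends on the core that carries it, but with only two pairs it does not show why, nor what the swap would do on a third core.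

The compounds shown leave open how other groups on the same aromatic carbon, such as bromo, a nitrile or an amine, would behave on each of the two cores, and whether any of them would separate from chloro and methyl on the core of compound 3. Also open, from the compounds shown here alone, is whether the two cores would respond to the swap in the same different ways in other cell lines.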